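The source may report more compounds than this note shows. Statements on the series, on what has been measured and on what is new or still open speak of the compounds shown alone.

In a functional assay on MCF7 cells (Homo sapiens) for antiproliferative activity, read by MTT assay, with a stated time of 48 h (on this read-out higher numbers stand for weaker inhibition and lower numbers for stronger inhibition), the three measured compounds gave the following numbers:

Compound 3 `CC(=O)Nc1ccc(-c2nc3c(c(=O)n(C)c(=O)n3C)n2-c2cccc(F)c2)cc1`: 1700 nM
Compound 2 `COc1ccc(-n2c(-c3ccc(NC(C)=O)cc3)nc3c2c(=O)n(C)c(=O)n3C)cc1F`: 2800 nM
Compound 1 `COC(=O)Nc1ccc(-c2nc3c(c(=O)n(C)c(=O)n3C)n2-c2ccc(OC)cc2)cc1`: 4200 nM

Compound 3 has the lowest of these three numbers. Compound 2 lies closest, within the scatter of compound 3, while compound 1 stands beyond the scatter and gives a higher number.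

Compound 4 `COc1ccc(-n2c(-c3ccc(NC(C)=O)cc3)nc3c2c(=O)n(C)c(=O)n3C)cc1` has not yet been measured. It differs from compound 3 by 4-methoxyphenyl in place of 3-fluorophenyl on an aromatic nitrogen.

Within the data shown here, only one measured step bears on this change: a 1.6-fold lower number from compound 2 to compound 3 (0.22 log units; within the scatter), in which hydrogen replaced methoxy on an aromatic carbon, a step that stayed within the scatter. Compound 2, which also carries a methoxy on the aryl attached to the ring nitrogen, sits within the scatter of compound 3. Compound 1 carries a 4-methoxyphenyl on that nitrogen but a different amide, so its value of 4200 nM only shows that such a compound can give a higher number.

Compound 4 is therefore expected to show a 1.5-fold higher number from compound 3 to compound 4 (0.17 log units; within the scatter), a step mostly within the scatter. The estimate for compound 4 is 2500 nM, with a range from 1200 nM to 5200 nM.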

Compound 4, half-maximal inhibitory concentration: 9400 nM
The estimate for compound 4 lay 3.8-fold (0.58 log units) below the measured number, and the stated range ends below it.
By their numbers in this assay, from the lowest: compounds 3, 2 and 1 (each within the scatter of the next, the first and the last beyond it); then compound 4.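

In this assay, among these compounds, the change from 3-fluorophenyl to 4-methoxyphenyl on the aromatic nitrogen proves larger than the earlier compounds suggested, with a 5.5-fold higher number from compound 3 to compound 4 (0.74 log units; beyond the scatter), a step beyond the scatter, while the earlier loss of methoxy in a 1.6-fold lower number from compound 2 to compound 3 (0.22 log units; within the scatter) stayed within it. The fluoro on the methoxy-bearing ring also counts, since hydrogen in its place gives a 3.4-fold higher number from compound 2 to compound 4 (0.53 log units; beyond the scatter). The other end of the molecule responds as well, for methyl in place of methoxy on the carbonyl carbon gives a 2.2-fold higher number from compound 1 to compound 4 (0.35 log units; beyond the scatter), which leaves compound 4 with the highest number of the four.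

Nothing at hand explains these steps. Going by these compounds, it remains open how an amine or a hydroxyl would fare on that aryl ring, and whether the methoxy on the carbonyl carbon would also lower the number in compound 3.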